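Fluoro on the anilino ring of a sulfonylated pyrrolidine

The source may report more compounds than this note shows. Statements on the series, on what has been measured and on what is new or still open speak of the compounds shown alone.

Measured compounds in a functional assay on HCC827 cells (Homo sapiens) for antiproliferative activity, read by MTT assay, with a stated time of 72 h; on this read-out higher numbers stand for weaker inhibition and lower numbers for stronger inhibition:
Compound 1, `CN1CCN(c2ccc(Nc3ncc4nc(Nc5ccccc5)n([C@H]5CCNC5)c4n3)cc2)CC1`, gives 530 nM.
Compound 2, `CNC(=O)CN1CC[C@H](n2c(Nc3ccccc3)nc3cnc(Nc4ccc(N5CCN(C)CC5)cc4)nc32)C1`, gives 170 nM.
Compound 3, `CN1CCN(c2ccc(Nc3ncc4nc(Nc5ccccc5)n([C@H]5CCN(S(=O)(=O)C6CC6)C5)c4n3)cc2)CC1`, gives 1.6 nM.

Among these three, compound 3 holds the lowest number, and both steps leading to it lie beyond the scatter: a 330-fold lower number from compound 1 to compound 3 (2.52 log units; beyond the scatter) and a 110-fold lower number from compound 2 to compound 3 (2.03 log units; beyond the scatter). The smaller step of a 3.1-fold lower number from compound 1 to compound 2 (0.49 log units; beyond the scatter) shows the same nitrogen responding modestly to a different group. All three measured steps concern the amine nitrogen in the ring; none touches the anilino part of the shared core.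

Compound 4, `CN1CCN(c2ccc(Nc3ncc4nc(Nc5ccc(F)cc5)n([C@H]5CCN(S(=O)(=O)C6CC6)C5)c4n3)cc2)CC1`, is compound 3 with one change: fluoro in place of hydrogen on an aromatic carbon. For the measured compounds named here, no measured pair varies this position, so there is no step from which to read off a direction. The change is small in what it counts, a single fluorine entering where a hydrogen leaves, and the data offer nothing that would point to a move beyond the scatter. The step of no change at the digits printed from compound 3 to compound 4 (within the scatter) is therefore expected to be essentially flat. In this assay, from the compounds shown here alone, compound 4 is estimated at 1.6 nM, with a range from 0.6 nM to 4.5 nM, because compound 3 gives 1.6 nM and the altered site is untested here.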

Compound 4, half-maximal inhibitory concentration: 7.5 nM
For compound 4 the middle estimate is 4.7-fold (0.67 log units) below the measured one, and the stated range ends below it.
By their numbers in this assay, from the lowest: compound 3; then compound 4; then compound 2; then compound 1.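

For the compounds shown here, the anilino ring of the shared core, which no earlier step touched, proves to be a place that responds in this assay: going from phenyl to 4-fluorophenyl gives a 4.7-fold higher number from compound 3 to compound 4 (0.67 log units; beyond the scatter), so even one fluorine entering on an aromatic carbon, para to a large group, moves the read-out towards weaker inhibition. The step is modest, yet it lies beyond the scatter, which shows that potency in this series depends on more than the group on the amine nitrogen in the ring. The data shown offer nothing that accounts for this step.

Going by these compounds alone, the single pair leaves open whether the loss belongs to fluoro itself or to any group at this carbon, and a chlorine, a methyl or a methoxy group there would begin to separate these two readings, as would fluoro on another carbon of the same ring. From the compounds shown here alone, it also remains open whether the step would keep its direction and size with hydrogen or (methylcarbamoyl)methyl in place of cyclopropylsulfonyl on the ring nitrogen.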